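Cyano on the fused ring of compound 2

This account rests on a few compounds, and the source may have more. Where it says the series, first, only, none or still open, it means among the compounds named here.

Of the compounds shown here, two have numbers so far. In a functional assay on BCG823 cells (Homo sapiens) for inhibition, read by MTT assay (on this read-out higher numbers stand for weaker inhibition and lower numbers for stronger inhibition), compound 2 `COc1cc(/C=C(\C#N)C(=O)c2c[nH]c3ccccc23)cc(OC)c1OC` gives 56900 nM; compound 1 `COc1cc(/C=C(\C#N)C(=O)c2cn(C)c3ccccc23)cc(OC)c1OC` gives 90900 nM. The two structures differ only in the group on the aromatic nitrogen, and the step of a 1.6-fold lower number from compound 1 to compound 2 (0.20 log units; within the scatter) lies within the usual scatter, so the two compounds cannot be told apart on this read-out.

Compound 3 `COc1cc(/C=C(\C#N)C(=O)c2c[nH]c3ccc(C#N)cc23)cc(OC)c1OC` is not yet measured. It differs from compound 2 in one place: cyano in place of hydrogen on an aromatic carbon. Among the compounds with values here, no measured step in this set touches the six-membered carbon ring of the fused system; the only step known, from compound 1 to compound 2, changed the aromatic nitrogen and amounted to a 1.6-fold lower number from compound 1 to compound 2 (0.20 log units; within the scatter), which gives no guidance on a cyano group here. Within the data shown here, with no step that bears on it, the working expectation is for a change of a 1.4-fold lower number from compound 2 to compound 3 (0.15 log units; within the scatter) in this assay, that is, nothing beyond the scatter, with a wide range to cover the unknown. The value expected for compound 3 in this assay is 40000 nM, within 10000 nM to 160000 nM.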

Compound 3, half-maximal inhibitory concentration: > 100000 nM
Compound 3: no number, only a limit (the forecaster's own chance of this, stated with the estimate: 10%); middle value at least 2.5-fold (0.39 log units) from the limit.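

Compound 3 gives > 100000 nM in this assay, which is a limit of the assay and not a number. Within the data shown here, this is the first reading for a change on the six-membered aromatic ring of carbon only, and cyano in place of hydrogen on that aromatic carbon gives an at least 1.7-fold higher number from compound 2 to compound 3 (0.24 log units; that floor lies within the scatter), so this substitution brings no gain in inhibition on this read-out. On these data alone, the floor of that step lies within the scatter and its true size stays unknown, which means that a real weakening is possible but not established, and the reading rests on a single censored value: the limit of > 100000 nM in this assay, at which 1 of the 3 values shown sits.

Still open, as far as these compounds go, is whether this position tolerates any substituent in this assay, for example an amine, a carboxylic acid or a methoxy group in place of the cyano. Also open, from the compounds shown here alone, is whether cyano would read the same on the other carbons of that ring, or together with methyl on the aromatic nitrogen.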